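This account rests on a few compounds, and the source may have more. Where it says the series, first, only, none or still open, it means among the compounds named here.

Measured compounds:
compound 1, `CCc1ccc(Nc2cc(NC(=O)Nc3cc(OC)cc(OC)c3)ncn2)cc1`: 78%
compound 2, `COc1ccc(Nc2cc(NC(=O)Nc3c(Cl)cccc3Cl)ncn2)cc1C`: 80.1%

In a functional assay on PC-9 cells (Homo sapiens) for inhibition, read by MTT assay, with a stated time of 48 h, tested at 10 uM (a lower number here means less inhibition, a higher number more inhibition at the concentration tested (going by the name of the read-out)), compound 1 gives 78% and compound 2 gives 80.1%. Going by the values given here, of these two numbers the one for compound 2 is the higher, but only by an amount within the usual scatter, so the two cannot be separated. Compound 3, `COc1cc(NC(=O)Nc2cc(Nc3ccc(OC)c(C)c3)ncn2)cc(OC)c1`, has not yet been measured in this assay. The change from compound 2 to compound 3 is 3,5-dimethoxyphenyl in place of 2,6-dichlorophenyl on an amide-type nitrogen. Among the compounds with values here, no measured pair differing in a single place is available, so the size of this step is not known from the data. Compound 1 already carries a 3,5-dimethoxyphenyl on its amide-type nitrogen and gives 78%, close to compound 2. The step of a number 2.1 percentage points lower from compound 2 to compound 3 (within the scatter) is therefore expected to be small and not beyond the scatter. Compound 3 is estimated at 78%, within 65% to 88%.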

Compound 3, a percentage reported as inhibition, at one concentration (the size of the read-out at that concentration, not a potency): 62%
Compound 3: the middle estimate sits 16 percentage points above what was measured; measured number below the stated range.
By their numbers in this assay, from the lowest: compound 3; then compounds 1 and 2 (each within the scatter of the next).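

In this assay, a number 18.1 percentage points lower from compound 2 to compound 3 (beyond the scatter) shows that, with the 4-methoxy-3-methylphenyl held constant, 3,5-dimethoxyphenyl in place of 2,6-dichlorophenyl on the amide-type nitrogen is not a neutral exchange. With the 3,5-dimethoxyphenyl held constant, the other place also matters: 4-methoxy-3-methylphenyl in place of 4-ethylphenyl on a nitrogen on an aromatic ring gives a number 16 percentage points lower from compound 1 to compound 3 (beyond the scatter). Nothing available explains either step.

The compounds shown leave open whether 2,6-dichlorophenyl on the amide-type nitrogen would give a similar step with 4-ethylphenyl on the other nitrogen. They also leave open how an unsubstituted phenyl or a single methoxy group on that ring, or a piperazine on the ring at the other nitrogen, would read in this assay.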